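Methyl in Place of Trifluoromethyl: Compound 2 to Compound 4

The source may report more compounds than this note shows. Statements on the series, on what has been measured and on what is new or still open speak of the compounds shown alone.

Of the compounds shown here, three on one shared core have been measured in a functional assay on HeLa cells (Homo sapiens) for cytotoxicity, read by MTT assay, with a stated time of 2 days; a lower number here means a stronger inhibitor, a higher number a weaker inhibitor. Compound 1 `Cc1ccc2nc(-c3cccc(OC(F)(F)F)c3)[nH]c(=O)c2c1` reports only a limit in this assay, > 50000 nM, and this limit is the limit of > 50000 nM in this assay, at which 1 of the 3 values shown sits. Compound 2 `Cc1ccc2nc(-c3ccccc3C(F)(F)F)[nH]c(=O)c2c1` gives 2450 nM in this assay. Compound 3 `Cc1ccc2c(=O)[nH]c(-c3ccccc3OC(F)(F)F)nc2c1` gives 18300 nM in this assay. Of the two numbers shown, compound 2 stands lowest, and the nearest number, that of compound 3, lies beyond the scatter above it. Compound 4 `Cc1ccc2nc(-c3ccccc3C)[nH]c(=O)c2c1` has not yet been measured in this assay. It differs from compound 2 in a single place: methyl in place of trifluoromethyl on an aromatic carbon. Among the measured compounds shown here, no measured pair shows this change, and the data give neither its size nor its direction. Compound 4 is expected to give a higher number than compound 2, with the step of a 2.4-fold higher number from compound 2 to compound 4 (0.39 log units; beyond the scatter) estimated to reach beyond the scatter. Compound 4 is estimated at 6000 nM, with a range from 1500 nM to 25000 nM.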

Compound 4, half-maximal inhibitory concentration: 4580 nM
Compound 4: the middle estimate sits 1.3-fold (0.12 log units) above what was measured; low and high end bracket the measured number.
By their numbers in this assay, from the lowest: compounds 2 and 4 (each within the scatter of the next); then compound 3. At a limit, above all of these: compound 1.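

In this assay, among the compounds shown here, this pair is the first direct reading of methyl in place of trifluoromethyl on an aromatic carbon ortho to a large group, and it gives a 1.9-fold higher number from compound 2 to compound 4 (0.27 log units; within the scatter) and so does not tell the two compounds apart. In this one pair, the loss of the three fluorine atoms leaves a measured number rather than a limit, and the number stays within the scatter of that of compound 2. Nothing among the data shown offers a cause for this result.

The compounds shown leave open how another group at this place, such as a chlorine atom, a methoxy group or an amine, would read. They also leave open whether the same exchange would give a similar step elsewhere on the shared core.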